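The source may report more compounds than this note shows. Statements on the series, on what has been measured and on what is new or still open speak of the compounds shown alone.

Among the compounds with values here, in a functional assay on DU-145 cells (Homo sapiens) for inhibition (a higher number here means a weaker inhibitor of growth, a lower number a stronger inhibitor of growth), two compounds built on one shared core have numbers so far. Compound 1 `NC(=O)c1cc(Cl)ccc1NC(=O)COc1ccccc1` gives 6010 nM, while compound 2 `NC(=O)c1cc(I)ccc1NC(=O)COc1ccccc1` gives 444 nM, the lower of the two numbers and so the stronger growth inhibitor of this pair. Within the data shown here, the one measured step, a 14-fold lower number from compound 1 to compound 2 (1.13 log units; beyond the scatter), is large and beyond the scatter, and it comes from iodo in place of chloro on an aromatic carbon.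

Compound 3 `COc1ccc(NC(=O)COc2ccccc2)c(C(N)=O)c1` has no number yet. It changes that same carbon again: methoxy in place of iodo on an aromatic carbon. In plain words, this is methoxy in place of iodo on an aromatic carbon.

Only the chloro-to-iodo step bears on this change, and it shows that the group at this carbon can move the number a long way. It says nothing directly about methoxy, so the forecast is uncertain. With iodo gone, a return towards the level of compound 1, at 6010 nM, seems the most likely outcome, which would be a large step towards a higher number. The expected step is a 10-fold higher number from compound 2 to compound 3 (1.01 log units; beyond the scatter). For compound 3 the estimated value is 4500 nM, with an expected range of 1300 nM to 16000 nM.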

Compound 3, concentration for 50% growth inhibition: 1870 nM
Compound 3: middle estimate off by 2.4-fold (0.38 log units), on the high side, and the stated range covers the measured number.
By their numbers in this assay, from the lowest: compound 2; then compound 3; then compound 1.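

In this assay, the new result separates methoxy from both halogens at this carbon: there is a 4.2-fold higher number from compound 2 to compound 3 (0.62 log units; beyond the scatter), yet also a 3.2-fold lower number from compound 1 to compound 3 (0.51 log units; beyond the scatter). Removing iodo therefore need not bring the number all the way back to the level of the chloro compound, and the three groups now rank iodo, methoxy, chloro, from the lowest number to the highest. The swap from iodo to methoxy also changes what is counted at this site, from one heavy atom and no hydrogen-bond acceptor to two heavy atoms and one acceptor, but nothing available here explains the ranking of these groups.

Going by these compounds, three groups on one carbon are too few to show what sets this order, so it remains open whether bromo, an amine or a longer chain such as ethoxy would give a number nearer to that of compound 2 or that of compound 1. On these data alone, it is also open whether the same ranking would hold with these groups on another carbon of this ring.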